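Moving the acetyl group on the anilino ring

A few compounds are considered here, and "the series" means these few. Any claim that something is new, unique, unknown or untested is made for them only; others in the source may bear on it.

Compound 1 `CCOC(=O)c1ccc(Nc2ccnc(SCC(=O)c3ccc(C#N)cc3)n2)cc1`: 82%
Compound 2 `CC(=O)c1cccc(Nc2ccnc(SCC(=O)c3ccc(-c4ccccc4)cc3)n2)c1`: 28%
Compound 3 `COc1ccc(C(=O)CSc2nccc(Nc3cccc(C(C)=O)c3)n2)cc1`: 46%

In a functional assay on CCRF-CEM cells (Homo sapiens) for inhibition, read by sulforhodamine B assay, with a stated time of 48 h, tested at 10 uM (a lower number here means less inhibition of growth, a higher number more inhibition of growth at the concentration tested), compound 2 gives 28%, the lowest of the three numbers; compound 3 lies a number 18 percentage points higher from compound 2 to compound 3 (beyond the scatter), and compound 1 stands furthest away. Compound 4 `CC(=O)c1ccc(Nc2ccnc(SCC(=O)c3ccc(-c4ccccc4)cc3)n2)cc1` differs from compound 2 by 4-acetylphenyl in place of 3-acetylphenyl on a nitrogen on an aromatic ring. Among the measured compounds shown here, no measured step covers this positional change: the only step known, a number 18 percentage points higher from compound 2 to compound 3 (beyond the scatter), concerns the other end of the molecule, and compound 1 carries a different group at both ends, so its value cannot be tied to the position alone. The expected step is therefore uncertain, and compound 4 is estimated at a number 12 percentage points higher from compound 2 to compound 4 (beyond the scatter). For compound 4 the estimate is 40%, with a range from 15% to 70%.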

Compound 4, percent growth inhibition at one concentration: 22%
Compound 4: the middle estimate sits 18 percentage points above what was measured; the measured number falls inside the stated range.
By their numbers in this assay, from the lowest: compounds 4 and 2 (each within the scatter of the next); then compound 3; then compound 1.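

Among the compounds shown here, compound 4 gives a direct reading of the acetyl position, which the earlier compounds could not. In this assay, 4-acetylphenyl in place of 3-acetylphenyl on the nitrogen gives a number 6 percentage points lower from compound 2 to compound 4 (within the scatter) while the rest of the molecule stays the same. Within this pair, moving the acetyl group therefore does not separate the two compounds, and no evidence here bears on the result.

Going by these compounds, it remains open whether the same holds with the methoxy group of compound 3 at the other end, and what an amine or a carboxylic acid would do in place of the acetyl group.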